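Aryl replacement at the amine of compound 1

A few compounds are considered here, and "the series" means these few. Any claim that something is new, unique, unknown or untested is made for them only; others in the source may bear on it.

Compound 1 `COc1cc(N(CC2CC2)c2ccccc2)cnc1C(=O)[C@H]1C[C@@H]1C(=O)O` stands at the top of the three numbers in an assay on isolated protein for inhibition of leukotriene C4 synthase (Homo sapiens), read by LC-MS, with stated times of 45 min and 20 min (on this read-out higher numbers stand for weaker inhibition and lower numbers for stronger inhibition), giving 1640 nM. Compound 3 `COc1cc(N(Cc2ccc(F)cc2)c2cccc(C(F)(F)F)c2)cnc1C(=O)[C@H]1C[C@@H]1C(=O)O` gives 157 nM and compound 2 `CCCN(c1cnc(C(=O)[C@H]2C[C@@H]2C(=O)O)c(OC)c1)c1ccc(F)c2ccccc12` gives 7.09 nM; both gaps to compound 1 lie beyond the scatter. Compound 4 `COc1cc(N(CC2CC2)c2cc(Cl)c(F)cc2F)cnc1C(=O)[C@H]1C[C@@H]1C(=O)O` differs from compound 1 in one place: 5-chloro-2,4-difluorophenyl in place of phenyl on a nitrogen on an aromatic ring. Going by the values given here, no step between measured compounds covers this exact change. The two measured compounds carrying substituted aryl groups on the same nitrogen, compound 2 and compound 3, both sit well under compound 1, so a downward step beyond the scatter is expected for compound 4, estimated as a 5.5-fold lower number from compound 1 to compound 4 (0.74 log units; beyond the scatter). Compound 4 is therefore expected to give about 300 nM, with a range from 80 nM to 1200 nM.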

Compound 4, half-maximal inhibitory concentration in the leukotriene C4 synthase assay: 27.6 nM
Beside the measured number, compound 4's estimate is 11-fold (1.04 log units) above it; measured number below the stated range.
By their numbers in the leukotriene C4 synthase assay, from the lowest: compound 2; then compound 4; then compound 3; then compound 1.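

In the leukotriene C4 synthase assay, 5-chloro-2,4-difluorophenyl in place of phenyl gives a 59-fold lower number from compound 1 to compound 4 (1.77 log units; beyond the scatter). Going by these compounds alone, this is the first single-place reading at this nitrogen, and it shows that the aryl group alone, with the rest of the structure held fixed, can carry a large step. In a physicochemical assay for lipophilicity, read by LC-MS, in phosphate buffer, measured as octanol-water partition, at pH 7.4 (a higher number here means a more lipophilic compound, a lower number a more polar compound), compound 1 gives 0.65 and compound 4 gives 1.1. The same change also gives a higher reading in the physicochemical assay: the measured distribution coefficient of compound 1, 0.65, and of compound 4, 1.1, a number 0.45 log units higher (beyond the scatter)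

As far as these compounds go, the chlorine and the two fluorines enter together, so their separate shares of the step remain open. Also open, from the compounds shown here alone, is whether a nitrile on this aryl ring would give a comparable step.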